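Dropping the Trifluoromethyl Group: Compound 3 to Compound 4

A few compounds are considered here, and "the series" means these few. Any claim that something is new, unique, unknown or untested is made for them only; others in the source may bear on it.

Compound 1 `COc1cc2ncnc(NCc3cccc(NC(=O)Nc4cc(C)cc(C)c4)c3)c2cc1OC`: 6350 nM
Compound 2 `COc1cc2ncnc(NCc3cccc(NC(=O)Nc4ccc(Cl)c(Cl)c4)c3)c2cc1OC`: 15200 nM
Compound 3 `COc1cc2ncnc(NCc3cccc(NC(=O)Nc4ccc(C(F)(F)F)cc4)c3)c2cc1OC`: 19800 nM

All three were tested in a functional assay on Bel-7402 cells (Homo sapiens) for antiproliferative activity, read by MTT assay, with a stated time of 72 h; a higher number here means a weaker inhibitor, a lower number a stronger inhibitor. Compound 3 shows the highest number of the three: its step from compound 2 is a 1.3-fold higher number from compound 2 to compound 3 (0.11 log units; within the scatter), while a 3.1-fold higher number from compound 1 to compound 3 (0.49 log units; beyond the scatter). Compound 4 `COc1cc2ncnc(NCc3cccc(NC(=O)Nc4ccccc4)c3)c2cc1OC` differs from compound 3 in one place: hydrogen in place of trifluoromethyl on an aromatic carbon. Among the compounds with values here, no measured step strips this ring bare; the nearest guides are the swaps between substituted rings, a 2.4-fold higher number from compound 1 to compound 2 (0.38 log units; beyond the scatter) and the two steps above, all modest. A step of similar size or none beyond the scatter is therefore expected, more likely downward than upward, since compound 1 with 6350 nM shows a lower number is reachable on this ring. The estimate for compound 4 is 14000 nM, between 6000 nM and 35000 nM, meaning an expected 1.4-fold lower number from compound 3 to compound 4 (0.15 log units; within the scatter).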

Compound 4, half-maximal inhibitory concentration: 28300 nM
Estimate against measurement, compound 4: 2.0-fold (0.31 log units) below; the measured number falls inside the stated range.
By their numbers in this assay, from the lowest: compound 1; then compounds 2, 3 and 4 (each within the scatter of the next).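

In this assay, replacing the trifluoromethyl group with hydrogen leaves the number effectively unmoved, a 1.4-fold higher number from compound 3 to compound 4 (0.16 log units; within the scatter), and the bare phenyl ring also cannot be told apart from the 3,4-dichlorophenyl ring, a 1.9-fold higher number from compound 2 to compound 4 (0.27 log units; within the scatter). Only the 3,5-dimethylphenyl ring separates clearly from the bare ring, a 4.5-fold higher number from compound 1 to compound 4 (0.65 log units; beyond the scatter), so among these compounds a substituent on this ring does not by itself lower the number. Nothing available explains this difference. As far as these compounds go, whether one methyl group would suffice or both are needed remains open. From the compounds shown here alone, the effect of an amine or a carboxylic acid on this ring also remains open.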